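Swapping the Aryl Group on a Fused Two-Ring Core

A few compounds are considered here, and "the series" means these few. Any claim that something is new, unique, unknown or untested is made for them only; others in the source may bear on it.

Of the compounds shown here, three sharing one core have been tested in a functional assay on U-251 cells (Homo sapiens) for inhibition, read by sulforhodamine B assay, with a stated time of 48 h, tested at 10 uM; on this read-out lower numbers stand for less inhibition and higher numbers for more inhibition at the one concentration tested (going by the name of the read-out). Compound 1 `O=Cc1ccc(-c2cn3ccnc3c(-c3ccc4ncn(C5CCCCC5)c4c3)n2)cc1` gives 32%. Compound 2 `CCc1ccc(-c2cn3ccnc3c(-c3ccc4ncn(Cc5ccccc5)c4c3)n2)cc1` gives 46.1%. Compound 3 `Cc1cccc(-c2cn3ccnc3c(-c3ccc4ncn(Cc5ccccc5)c4c3)n2)c1` gives 19.4%, the lowest of the three numbers, with compound 1 nearest and compound 2 furthest, both differences beyond the scatter.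

Compound 4 `O=Cc1ccc(-c2cn3ccnc3c(-c3ccc4ncn(Cc5ccccc5)c4c3)n2)cc1` is the next step. Its change from compound 3 is 4-formylphenyl in place of 3-methylphenyl on an aromatic carbon, on an aromatic carbon of the core. For the measured compounds named here, the one measured step that touches the same position, a number 26.7 percentage points lower from compound 2 to compound 3 (beyond the scatter), shows that this aryl group alone can move the read-out by a modest but real amount. Compound 4 also carries the same 4-formylphenyl as compound 1, differing from it only in the group on the other side of the core, and compound 1 sits above compound 3. An upward step of similar size is therefore expected, a number 14.6 percentage points higher from compound 3 to compound 4 (beyond the scatter). Compound 4 is estimated at 34%, within a range from 15% to 55%.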

Compound 4, a percentage reported as inhibition, at one concentration (the size of the read-out at that concentration, not a potency): 32%
Beside the measured number, compound 4's estimate is 2 percentage points above it; the range from low to high includes it.
By their numbers in this assay, from the lowest: compound 3; then compounds 1 and 4 (each within the scatter of the next); then compound 2.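

In this assay, the aryl position now holds three groups on the same benzyl-bearing background, and the read-out changes with each of them: a number 12.6 percentage points higher from compound 3 to compound 4 (beyond the scatter) and a number 14.1 percentage points lower from compound 2 to compound 4 (beyond the scatter). This places the 4-formylphenyl compound in the middle of the three, so the position responds to more than one kind of group. The other side of the core behaves differently with 4-formylphenyl in place, where benzyl in place of cyclohexyl on the aromatic nitrogen gives no change at the digits printed from compound 1 to compound 4 (within the scatter), and no measurement on hand offers an explanation for any of these steps.

Compounds 2 and 3 differ in both the group and where it sits on the phenyl ring, so those two effects remain tangled, and whether the benzyl and cyclohexyl groups also match with 4-ethylphenyl is open. An amine or a carboxylic acid in place of the formyl group would test this position further.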